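This account rests on a few compounds, and the source may have more. Where it says the series, first, only, none or still open, it means among the compounds named here.

Measured in a functional assay on K562 cells (Homo sapiens) for inhibition, read by MTT assay, with a stated time of 48 h; on this read-out higher numbers stand for weaker inhibition and lower numbers for stronger inhibition:
- compound 1 `CC(C)(C)OC(=O)N1C[C@@H](n2cc(-c3ccc4nc(N)sc4n3)nn2)C[C@H]1C(=O)Nc1ccc(Cl)c(C(F)(F)F)c1` gives 10900 nM
- compound 2 `CC(C)(C)OC(=O)N1C[C@@H](n2cc(-c3ccc4nc(N)sc4n3)nn2)C[C@H]1C(=O)Nc1ccc(Br)cc1` gives 29200 nM
- compound 3 `CC(C)(C)OC(=O)N1C[C@@H](n2cc(-c3ccc4nc(N)sc4n3)nn2)C[C@H]1C(=O)Nc1ccc(F)c(F)c1` gives 26400 nM

Compound 2 stands at the weak end of this small set, together with compound 3. That pair is not separated: a 1.1-fold lower number from compound 2 to compound 3 (0.04 log units; within the scatter). Compound 1 lies on the stronger side of both: a 2.7-fold higher number from compound 1 to compound 2 (0.43 log units; beyond the scatter) and a 2.4-fold higher number from compound 1 to compound 3 (0.38 log units; beyond the scatter).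

The next compound is compound 4 `Nc1nc2ccc(-c3cn([C@@H]4CN[C@H](C(=O)Nc5ccc(Br)cc5)C4)nn3)nc2s1`, which differs from compound 2 at a single place: hydrogen in place of tert-butoxycarbonyl on an amine nitrogen in a ring. In words, hydrogen stands in place of tert-butoxycarbonyl on an amine nitrogen in a ring.

Going by the values given here, none of the measured steps bears directly on this change. All three exchange the aryl group on the amide-type nitrogen, and all three compounds keep the tert-butoxycarbonyl group. Among the compounds with values here, they show only that changes elsewhere have been small, with a 2.7-fold higher number from compound 1 to compound 2 (0.43 log units; beyond the scatter) and a 2.4-fold higher number from compound 1 to compound 3 (0.38 log units; beyond the scatter) both modest. The data give no direction for removing the group, so the working expectation in this assay is no shift beyond the scatter, with wide uncertainty on either side. The estimated step is a 1.2-fold lower number from compound 2 to compound 4 (0.07 log units; within the scatter). For compound 4 the expected value is 25000 nM, with an estimated range from 8000 nM to 75000 nM.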

Compound 4, half-maximal inhibitory concentration: 24400 nM
Compound 4: middle estimate off by 1.0-fold (0.01 log units), on the high side; measured number inside the range.
By their numbers in this assay, from the lowest: compound 1; then compounds 4, 3 and 2 (each within the scatter of the next).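

In this assay, taking the tert-butoxycarbonyl group off the amine nitrogen of the five-membered non-aromatic ring gives a 1.2-fold lower number from compound 2 to compound 4 (0.08 log units; within the scatter), so the two numbers are not separated. Going by these compounds alone, this is the first reading at this nitrogen, as the earlier compounds all keep the group and speak only to the aryl group on the amide-type nitrogen. With the 4-bromophenyl amide in place, then, neither the group's seven heavy atoms nor its two hydrogen-bond acceptors make a difference that can be read here, and no supporting data offer an explanation for this result.

Within the data shown here, the reading rests on one pair and so leaves open whether hydrogen and tert-butoxycarbonyl would also fall together with the 4-chloro-3-(trifluoromethyl)phenyl group of compound 1, the one aryl group in this set that stands apart from the others. It also leaves open how a methyl or acetyl group on this ring nitrogen, or a carboxylic acid carried on a short chain there, would read against hydrogen and tert-butoxycarbonyl.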